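Removing the Chloro Group from Compound 1

This account rests on a few compounds, and the source may have more. Where it says the series, first, only, none or still open, it means among the compounds named here.

Compound 1 `COc1cc(-n2cc(-c3ccc(Cl)cc3)[nH]c2=O)cc(OC)c1OC` gives 20000 nM
Compound 2 `COc1ccc(-c2cn(-c3ccc(Cl)cc3)c(=S)[nH]2)cc1OC` gives 39800 nM
Compound 3 `COc1ccc(-n2cc(-c3ccc(OC)c(OC)c3)[nH]c2=S)cc1Cl` gives > 100000 nM (a limit)

All three entries come from a functional assay on UO-31 cells (Homo sapiens) for antiproliferative activity (a higher number here means a weaker inhibitor of growth, a lower number a stronger inhibitor of growth), and describe growth inhibition. For the measured compounds named here, compound 1 holds one of only two true numbers in the set, and it lies within the usual scatter of compound 2, so the two cannot be ranked. Compound 3 is reported only as a limit, > 100000 nM and no more than that.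

The next compound to be tested is compound 4 `COc1cc(-n2cc(-c3ccccc3)[nH]c2=O)cc(OC)c1OC` and it departs from compound 1 at a single place. The counted difference is hydrogen in place of chloro on an aromatic carbon and it reads 4-chlorophenyl to phenyl, with hydrogen in place of chloro on an aromatic carbon, para to a large group.

Going by the values given here, no measured pair in this small set differs at just one place, so the data offer no direct precedent for this change. Compound 1 at 20000 nM is therefore the only anchor, and no step beyond the scatter is expected in this assay in either direction. The estimated change is a 1.3-fold higher number from compound 1 to compound 4 (0.10 log units; within the scatter) and it stays small. For compound 4 the expected value is 25000 nM with an estimated range from 9000 nM to 70000 nM before the measurement is known.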

Compound 4, concentration for 50% growth inhibition: 39800 nM
For compound 4 the middle estimate is 1.6-fold (0.20 log units) below the measured one; the range from low to high includes it.
By their numbers in this assay, from the lowest: compounds 1, 2 and 4 (each within the scatter of the next). At a limit, above all of these: compound 3.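

In this assay, for the compounds shown here, this is the first pair in the set that differs at a single place, which gives a direct reading of the change from 4-chlorophenyl to phenyl: a 2.0-fold higher number from compound 1 to compound 4 (0.30 log units; within the scatter). Hydrogen in place of chloro on an aromatic carbon, para to a large group, therefore cannot be told apart from the parent in this measurement, and the chloro group is not shown to be required for the growth inhibition seen with compound 1. Nothing measured here bears on why the step has this size.

Whether another group at this place, such as fluoro, methoxy, an amine or a carboxylic acid, would move the number beyond the scatter remains open, as only chloro and hydrogen are shown there on this core. Going by these compounds, it is equally open whether hydrogen in place of chloro would read the same way on compound 2, which also carries a 4-chlorophenyl group but has no partner that differs from it at that one place.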